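The compounds below may be only part of what the source reports. "The series", "measured", "known", "first", "only" and "open" are said of these compounds alone.

Measured in a functional assay on A2780 cells (Homo sapiens) for antiproliferative activity, read by MTT assay, with a stated time of 48 h; on this read-out higher numbers stand for weaker inhibition and lower numbers for stronger inhibition:
- compound 1 `COc1ccc(-c2cc3c(cn2)[nH]c(=O)n3-c2cc(OC)c(OC)c(OC)c2)cc1O` gives 240 nM
- compound 2 `COc1ccc(-c2cc3c(cn2)n(C(C)C)c(=O)n3-c2cc(OC)c(OC)c(OC)c2)cc1O` gives 3160 nM

Of these two, compound 2 has the higher number (3160 nM). Compound 3 `COc1ccc(-c2cc3c(cn2)n(CC(N)=O)c(=O)n3-c2cc(OC)c(OC)c(OC)c2)cc1O` carries carbamoylmethyl in place of isopropyl on an aromatic nitrogen. Among the measured compounds shown here, one measured step bears on this nitrogen (a 13-fold higher number from compound 1 to compound 2 (1.12 log units; beyond the scatter)), and it is large and beyond the scatter. It compares isopropyl only with hydrogen, and no carbamoylmethyl value exists, so the direction remains uncertain. In this assay a modest move towards lower numbers is expected (a 2.6-fold lower number from compound 2 to compound 3 (0.42 log units; beyond the scatter)). The expected value for compound 3 is 1200 nM (estimated range 250 nM to 5000 nM).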

Compound 3, half-maximal inhibitory concentration: 9880 nM
The estimate for compound 3 lay 8.2-fold (0.92 log units) below the measured number; the measured number lies above the stated range.
By their numbers in this assay, from the lowest: compound 1; then compound 2; then compound 3.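

In this assay carbamoylmethyl on this aromatic nitrogen does not bring the number back towards that of the hydrogen compound; it moves further away (a 3.1-fold higher number from compound 2 to compound 3 (0.50 log units; beyond the scatter); a 41-fold higher number from compound 1 to compound 3 (1.61 log units; beyond the scatter)). Both substituents shown here, with and without a hydrogen-bond donor, give higher numbers than hydrogen, and the amide-bearing group gives the highest. No measurement available here accounts for this order.

As far as these compounds go, whether methyl, the smallest alkyl replacement, stays close to hydrogen remains open. So does the effect of an amine or a carboxylic acid on a chain at this nitrogen.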